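The compounds below may be only part of what the source reports. "The series", "measured", "known", "first", "only" and "open" are said of these compounds alone.

Measured in a functional assay on HT-29 cells (Homo sapiens) for inhibition, read by MTT assay; a lower number here means a stronger inhibitor, a higher number a weaker inhibitor:
compound 1 `COc1ccc(/C=C2\c3cc(OC)c(OC)c(OC)c3CC[C@H]2O)cc1O`: 790 nM
compound 2 `COc1ccc(/C=C2\c3cc(OC)c(OC)c(OC)c3CC[C@H]2O)cc1C(N)=O`: 550 nM
compound 3 `COc1ccc(/C=C2\c3cc(OC)c(OC)c(OC)c3CC[C@H]2O)cc1[N+](=O)[O-]`: > 10000 nM

In this assay, compound 3 gives only a limit, > 10000 nM, and not a number. Among the measured compounds shown here, it is the sole compound in this set without a number: the limit of > 10000 nM in this assay, at which 1 of the 3 values shown sits.

The next compound is compound 4 `COc1ccc(/C=C2\c3cc(OC)c(OC)c(OC)c3CC[C@H]2O)cc1C`. The structural change is methyl in place of nitro on an aromatic carbon. In words, methyl replaces nitro on an aromatic carbon, ortho to a methoxy group.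

For the measured compounds named here, two measured steps bear directly on leaving nitro, and both are large and run into the limit: an at least 12-fold higher number from compound 1 to compound 3 (1.10 log units; beyond the scatter) and an at least 18-fold higher number from compound 2 to compound 3 (1.25 log units; beyond the scatter). Between the other two groups, the step stays within the scatter: a 1.4-fold lower number from compound 1 to compound 2 (0.16 log units; within the scatter). Among these three compounds, only nitro goes with a number at the limit. Going by the values given here, no measured compound carries methyl at this place, so its return toward the level of compound 1 and compound 2 is uncertain, and the range is kept wide. Read in reverse, the two large steps point to a substantial move toward a lower number, and the estimated step is an at least 6.6-fold lower number from compound 3 to compound 4 (0.82 log units; beyond the scatter). Compound 4 is estimated at 1500 nM, with an expected range of 300 nM to 8000 nM.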

Compound 4, half-maximal inhibitory concentration: 3970 nM
Compound 4: the middle estimate sits 2.6-fold (0.42 log units) below what was measured, and the stated range covers the measured number.
By their numbers in this assay, from the lowest: compounds 2 and 1 (each within the scatter of the next); then compound 4. At a limit, above all of these: compound 3.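

In this assay, among the compounds shown here, methyl is the first group at this place, on an aromatic carbon ortho to a methoxy group, to give a measured number clearly apart from both hydroxy and carbamoyl: the data show a 5.0-fold higher number from compound 1 to compound 4 (0.70 log units; beyond the scatter) and a 7.2-fold higher number from compound 2 to compound 4 (0.86 log units; beyond the scatter). Compound 3 remains a limit and not a number, so an at least 2.5-fold lower number from compound 3 to compound 4 (0.40 log units; beyond the scatter) fixes only a minimum size for that step and not the step itself: the limit of > 10000 nM in this assay, at which 1 of the 4 values shown sits. Both nitro and methyl count no hydrogen-bond donors yet lie apart, so across these four compounds that count alone does not place a group, and the position now shows three levels: hydroxy and carbamoyl together, methyl higher, and nitro at the limit.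

On these data alone, it remains open where an amine or a carboxylic acid at this place would fall relative to these three levels, and whether a longer chain in place of methyl would move the number further from that of hydroxy and carbamoyl. As far as these compounds go, the true size of the gap between methyl and nitro also remains open, as does what separates these groups.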